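This account rests on a few compounds, and the source may have more. Where it says the series, first, only, none or still open, it means among the compounds named here.

Among the measured compounds shown here, compound 1 `O=C(CCC1CCCC1)N(O)c1ccc(Cl)cc1` has the lowest of the three numbers so far in a functional assay on MIA PaCa-2 cells (Homo sapiens) for inhibition (a higher number here means a weaker inhibitor, a lower number a stronger inhibitor), where compound 1 gives 7000 nM. For the measured compounds named here, compound 3 `O=C(CC1CCCCC1)N(O)c1ccc(Cl)cc1` gives 8000 nM in this assay; the step of a 1.1-fold higher number from compound 1 to compound 3 (0.06 log units; within the scatter) is the one measured change on this chain. Going by the values given here, compound 2 `O=C(C1CCCCC1)N(O)c1ccc(Cl)cc1` gives 20000 nM in this assay; no single step links it to compound 1, so its value stands on its own. Compound 4 `O=C(CCC1CCCCC1)N(O)c1ccc(Cl)cc1` differs from compound 1 by cyclohexyl in place of cyclopentyl on a saturated chain carbon, two bonds along the chain from a carbonyl carbon. Among the compounds with values here, the only measured step that bears on this change was within the scatter, so a step of no more than the scatter is expected in this assay, with no direction claimed. Compound 4 is therefore expected to give 6000 nM in this assay, in the range 2500 nM to 15000 nM, and the expected step is a 1.2-fold lower number from compound 1 to compound 4 (0.07 log units; within the scatter).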

Compound 4, half-maximal inhibitory concentration: 10000 nM
The estimate for compound 4 lay 1.7-fold (0.22 log units) below the measured number; low and high end bracket the measured number.
By their numbers in this assay, from the lowest: compounds 1, 3, 4 and 2 (each within the scatter of the next, the first and the last beyond it).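

Cyclohexyl in place of cyclopentyl on a saturated chain carbon, two bonds along the chain from a carbonyl carbon, gives a 1.4-fold higher number from compound 1 to compound 4 (0.15 log units; within the scatter) in this assay. At this position, the six-membered ring and the five-membered ring do not separate compound 1 and compound 4 beyond the scatter. No measurement here gives a cause for this result.

Open, going by these compounds, is whether phenyl in place of cyclohexyl, an amine on that ring or a longer chain would move the number beyond the scatter from compound 1.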